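Swapping an acid-bearing side chain for an aryl ether

A few compounds are considered here, and "the series" means these few. Any claim that something is new, unique, unknown or untested is made for them only; others in the source may bear on it.

Measured compounds:
compound 1 `CC(C)C(NC(=O)C(CC(=O)O)NC(=O)CCCOc1ccc(C(=N)N)cc1)C(=O)O` with 1.29
compound 2 `CC(C)CC(NC(=O)C(CC(=O)O)NC(=O)CCCOc1ccc(C(=N)N)cc1)C(=O)O` with 1.47
compound 3 `CC(C)(C)CC(NC(=O)C(CC(=O)O)NC(=O)CCCOc1ccc(C(=N)N)cc1)C(=O)O` with 1.59

All three share one core and differ only in the group on the saturated chain carbon bound to an amide-type nitrogen and a carbonyl carbon. In a physicochemical assay for lipophilicity (on this read-out lower numbers stand for lower lipophilicity and higher numbers for higher lipophilicity), compound 1 gives the lowest of the three numbers; compound 2 gives 1.47 and compound 3 gives 1.59, both so close to compound 1 that no order among the three can be read from them.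

The new compound 4 `Cc1ccc(OCCNC(=O)C(CC(=O)O)NC(=O)CCCOc2ccc(C(=N)N)cc2)cc1C` changes compound 1 at a different spot: 2-(3,4-dimethylphenoxy)ethyl in place of 1-carboxy-2-methylpropyl on an amide-type nitrogen. Two of the measured steps touch the same general idea, adding carbon to a side chain: a number 0.18 log units higher from compound 1 to compound 2 (within the scatter) and a number 0.30 log units higher from compound 1 to compound 3 (within the scatter). Both went upward in this assay, yet both stayed within the scatter. The present change is larger in kind, since more carbon enters, an aromatic ring enters, and a hydrogen-bond donor leaves. Because of the direction shown by a number 0.30 log units higher from compound 1 to compound 3 (within the scatter), an upward step is expected, and a considerably larger one than anything measured so far, estimated as a number 1.51 log units higher from compound 1 to compound 4 (beyond the scatter). Compound 4 is therefore expected to give about 2.8, likely between 2 and 3.6.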

Compound 4, partition coefficient: 1.43
Beside the measured number, compound 4's estimate is 1.37 log units above it, outside the stated range (below it).
By their numbers in this assay, from the lowest: compounds 1, 4, 2 and 3 (each within the scatter of the next).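

At the amide-type nitrogen, 2-(3,4-dimethylphenoxy)ethyl replaces 1-carboxy-2-methylpropyl, so a six-membered aromatic ring of carbon enters and a hydrogen-bond donor leaves, and in this assay this swap gives a number 0.14 log units higher from compound 1 to compound 4 (within the scatter) as its result. Among the compounds shown here, measured against the other two side chains, the swap gives a number 0.04 log units lower from compound 2 to compound 4 (within the scatter) and a number 0.16 log units lower from compound 3 to compound 4 (within the scatter) as well, so all four compounds lie within the scatter of their neighbours, and this much larger change in structure produces no step that can be told apart from the small changes to the carbon side chain among compounds 1, 2 and 3. No measurement is available that could explain why these numbers stay so close together.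

On these data alone, in compound 4, the aromatic ring, the ether oxygen and the loss of the carboxylic acid all arrive in a single change, so what each contributes to this read-out stays open. A plain benzyl group, or a 2-(3,4-dimethylphenoxy)ethyl chain that also carries a carboxylic acid, on the same nitrogen would help to separate these contributions.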